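This account rests on a few compounds, and the source may have more. Where it says the series, first, only, none or still open, it means among the compounds named here.

Compound 1 `Cc1ccc2oc(=O)c(-c3ccc(Cl)nn3)cc2c1` and compound 2 `Cc1cccc2cc(-c3ccc(Cl)nn3)c(=O)oc12` are built from the same atoms joined differently; the difference between the two cores is not broken down here. In an assay on cells for inhibition of Amine oxidase [flavin-containing] B (Homo sapiens), read by fluorescence and Amplex Red, with a stated time of 15 min (a lower number here means a stronger inhibitor, a higher number a weaker inhibitor), compound 1 gives 13500 nM and compound 2 gives 22700 nM, two values that lie within the scatter of each other. Compound 3 `COc1ccc(-c2cc3cc(C)ccc3oc2=O)nn1` is compound 1 with methoxy in place of chloro on an aromatic carbon and in this assay compound 3 gives 17600 nM, a step of a 1.3-fold higher number from compound 1 to compound 3 (0.12 log units; within the scatter). Compound 4 `COc1ccc(-c2cc3cccc(C)c3oc2=O)nn1` carries the same kind of change on the core of compound 2, namely (methoxy in place of chloro on an aromatic carbon); the surroundings of the place read alike in both cases. The earlier change gave a 1.3-fold higher number from compound 1 to compound 3 (0.12 log units; within the scatter). On that basis the step from compound 2 to compound 4 is expected to be about a 1.3-fold higher number from compound 2 to compound 4 (0.11 log units; within the scatter). Compound 4 is therefore estimated at 29000 nM, with a range from 14000 nM to 60000 nM.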

Compound 4, half-maximal inhibitory concentration: 5350 nM
The estimate for compound 4 lay 5.4-fold (0.73 log units) above the measured number, outside the stated range (below it).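

In this assay, methoxy in place of chloro on an aromatic carbon gives a 4.2-fold lower number from compound 2 to compound 4 (0.63 log units; beyond the scatter), a drop in the number that is not seen on the core of compound 1. The change therefore does not carry over as one fixed step between these two cores: the same change on two cores in this assay, a 1.3-fold higher number (0.12 log units; within the scatter) from compound 1 to compound 3 and a 4.2-fold lower number (0.63 log units; beyond the scatter) from compound 2 to compound 4, 5.5-fold (0.74 log units) apart, beyond the scatter of two such steps. Among these compounds, with one pair per core, this shows only that the two cores differ in their response; it does not show what in the cores sets that difference, or how the change would read on a further core.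

Still open, going by these compounds, is whether an amine or a longer alkoxy chain at the same place would split the two cores in the same way.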